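Swapping the group on the ring amide nitrogen

This account rests on a few compounds, and the source may have more. Where it says the series, first, only, none or still open, it means among the compounds named here.

Measured so far in a functional assay on HOS-TE85 cells (Homo sapiens) for inhibition, read by CCK-8 assay, with a stated time of 72 h; on this read-out lower numbers stand for stronger inhibition and higher numbers for weaker inhibition:
- compound 1, `CC1SC(c2cccc(C(=O)NCCCCc3ccccc3)c2)N(c2ccc(C3CC3)cc2)C1=O`, gives 191 nM
- compound 2, `COc1ccccc1N1C(=O)C(C)SC1c1cccc(C(=O)NCCCCc2ccccc2)c1`, gives 45.1 nM
- compound 3, `O=C(NCCCCc1ccccc1)c1cccc(C2SCC(=O)N2c2ccc(-c3ccccc3)cc2)c1`, gives > 1000 nM, which is a limit of the assay and not a number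

Compound 3 therefore stands at the weak end of the series: it is the one of the three that returned only (the limit of > 1000 nM in this assay, at which 1 of the 3 values shown sits), while compound 1 and compound 2 both gave numbers.

Compound 4, `COc1ccc(OC)c(N2C(=O)CSC2c2cccc(C(=O)NCCCCc3ccccc3)c2)c1`, keeps the rest of compound 3 and differs only at the ring amide nitrogen: 2,5-dimethoxyphenyl in place of 4-phenylphenyl on an amide-type nitrogen in a ring.

Within the data shown here, the one measured step that touches the same position is a 4.2-fold lower number from compound 1 to compound 2 (0.63 log units; beyond the scatter). There a methoxyphenyl entering for a larger carbon-only aryl group went with a modest gain. The change to compound 4 is of the same kind, a dimethoxyphenyl entering for 4-phenylphenyl, so a step of comparable size in the same direction is expected for compound 4, though starting from a limit the size is uncertain. The expected step is an at least 3.3-fold lower number from compound 3 to compound 4 (0.52 log units; beyond the scatter). Compound 4 is estimated at 300 nM, within 60 nM to 1500 nM.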

Compound 4, half-maximal inhibitory concentration: > 1000 nM
Compound 4 gave a limit, no number; the forecaster's own chance of this, stated with the estimate: 30%; middle value at least 3.3-fold (0.52 log units) away from the limit.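

Compound 3 and compound 4 both return only a limit of the assay, not a number, so no step can be read between them: the limit of > 1000 nM in this assay, at which 2 of the 4 values shown sit.

The compounds shown leave open how far beyond that limit each one lies, and so whether 2,5-dimethoxyphenyl in place of 4-phenylphenyl changes the read-out at all.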